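The source may hold more compounds than are shown below. What is called first, only, known or untested is meant among the compounds shown, and "the series" means these compounds.

The shared core is that of compound 1 `C=C[C@@H]1O[C@H](COCc2ccccc2)[C@@H](OCc2ccccc2)[C@H](OCc2ccccc2)[C@H]1O`. In a functional assay on HL-60 cells (Homo sapiens) for antiproliferative activity, read by MTT assay (on this read-out higher numbers stand for weaker inhibition and lower numbers for stronger inhibition), compound 1 gives 11800 nM, a weak result on this read-out. Compound 2 `CC(C)C[C@H]1O[C@H](COCc2ccccc2)[C@@H](OCc2ccccc2)[C@H](OCc2ccccc2)[C@@H]1O` belongs to the same series, but in this assay compound 2 was reported as "not active" (no number reported), with no number attached, so it stands at the weak end without a value that can be set against compound 1. Compound 3 `CC(C)C[C@@H]1O[C@H](COCc2ccccc2)[C@H](OCc2ccccc2)[C@H](OCc2ccccc2)[C@H]1O` has not yet been tested in this assay. Against compound 2, compound 3 shows (the two compounds have the same atoms and bonds and differ only in configuration as drawn: 3 of 5 stereo elements differ; a stereocentre at a saturated ring carbon is drawn R in compound 2 and S in compound 3; a stereocentre at a saturated ring carbon is drawn R in compound 2 and S in compound 3; a stereocentre at a saturated ring carbon is drawn R in compound 2 and S in compound 3). Going by the values given here, no measured step accompanies this kind of change, and since compound 2 has no number there is no anchor for how large a step in this assay to expect or in which direction. The working expectation is that compound 3 remains weak, with a real chance that this assay once more reports no number. Compound 3 is estimated to give 25000 nM, within a range from 5000 nM to 100000 nM.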

Compound 3, half-maximal inhibitory concentration: "not active" (no number reported)
The entry for compound 3 holds no number; no gap can be computed for the estimate.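

Neither compound 2 nor compound 3 carries a number in this assay, so no step can be read between them, and only this is certain: the fact that compounds 2 and 3 differ only in the configuration as drawn. The compounds shown leave open whether this change in configuration has any effect in this assay.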